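Selenocyanate Carbamates: A Methoxy for a Fluoro

The source may report more compounds than this note shows. Statements on the series, on what has been measured and on what is new or still open speak of the compounds shown alone.

Three aryl selenocyanate and diselenide carbamates have been measured in a functional assay on CCRF-CEM cells (Homo sapiens) for cytotoxicity, read by MTT assay, with a stated time of 72 h; on this read-out higher numbers stand for lower toxicity in this test and lower numbers for higher toxicity in this test. Compound 1 `N#C[Se]c1ccc(NC(=O)Oc2ccc(F)cc2)cc1` gives 71100 nM. Compound 2 `CCCCCCOC(=O)Nc1ccc([Se]C#N)cc1` gives 72700 nM, and compound 3 `O=C(Nc1ccc([Se][Se]c2ccc(NC(=O)Oc3ccc(F)cc3)cc2)cc1)Oc1ccc(F)cc1` gives 68800 nM. Compound 1 sits within the usual scatter of both companions in this assay, so the three numbers are indistinguishable here, and no single change between two measured compounds can be traced.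

The next compound, compound 4 `COc1ccc(OC(=O)Nc2ccc([Se]C#N)cc2)cc1`, differs from compound 1 in one place: methoxy in place of fluoro on an aromatic carbon. Within the data shown here, no measured pair in this set shows such a change, so nothing in the data gives a direction for it. Given that compound 1 gives 71100 nM and its two companions fall within the scatter of that figure, the step from compound 1 to compound 4 is expected to be small, a 1.0-fold lower number from compound 1 to compound 4 (0.01 log units; within the scatter), with no shift beyond the scatter in either direction. Compound 4 is therefore estimated at 70000 nM in this assay, with a range from 35000 nM to 140000 nM.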

Compound 4, concentration lethal to 50% of the cells: 70000 nM
Compound 4: middle estimate and measured number agree at the digits printed; the range from low to high includes it.
By their numbers in this assay, from the lowest: compounds 3, 4, 1 and 2 (each within the scatter of the next).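

In this assay the set now holds its first readable single change: methoxy in place of fluoro on an aromatic carbon, para to a large group (a 1.0-fold lower number from compound 1 to compound 4 (0.01 log units; within the scatter)). Among these compounds, at this position, then, exchanging fluoro, 1 heavy atom, for methoxy, 2 heavy atoms and 1 hydrogen-bond acceptor, leaves the number within the scatter, something the earlier compounds, with no pair differing in one place, could not show. Nothing measured here bears on why this step is so small.

As far as these compounds go, whether an amine, a carboxylic acid or a longer chain at this same place would move the number beyond the scatter stays open. Also open, from the compounds shown here alone, is whether methoxy in place of fluoro would behave the same way on the diselenide of compound 3.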